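Replacing the furan-3-yl group of compound 1

The source may report more compounds than this note shows. Statements on the series, on what has been measured and on what is new or still open speak of the compounds shown alone.

Compound 1 `CC1=C(CCc2ccoc2)[C@@]2(C)CCC(=O)C(C)(C)C2=C(O)C1=O`: > 50000 nM (a limit)
Compound 2 `CC1=C(CCc2ccoc2)[C@@]2(C)CCC(=O)C(C)(C)[C@@H]2[C@@H](O)C1=O`: > 50000 nM (a limit)

Both compounds were tested in a functional assay on RAW264.7 cells (Mus musculus) for inhibition, read by Griess assay, with stated times of 2 h and 18 h (on this read-out higher numbers stand for weaker inhibition and lower numbers for stronger inhibition), and neither gave a number. Compound 1 stands at > 50000 nM in this assay as a limit of the assay. Among the measured compounds shown here, the measured set therefore offers only the limit of > 50000 nM in this assay, at which 2 of the 2 values shown sit, and no step between compounds.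

Compound 3 `CO[C@H]1C=C(CCC2=C(C)C(=O)C(O)=C3C(C)(C)C(=O)CC[C@]23C)C(=O)O1` keeps the core of compound 1 and changes one group: a group of 8 heavy atoms (5 carbon, 3 oxygen; one five-membered non-aromatic ring with 1 hetero atom) in place of a group of 5 heavy atoms (4 carbon, 1 oxygen; one five-membered aromatic ring with 1 hetero atom), on a saturated chain carbon, two bonds along the chain from a double-bonded ring carbon. For the measured compounds named here, no measurement yet shows what such an exchange does in this assay, so any expectation here is weakly grounded. A modest move towards stronger inhibition is expected in an at least 1.6-fold lower number from compound 1 to compound 3 (0.22 log units; that floor lies within the scatter), and the result may well be only a limit again. For compound 3 the estimated value is 30000 nM, with an expected range from 12000 nM to 50000 nM in this read-out.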

Compound 3, half-maximal inhibitory concentration: > 50000 nM
Compound 3: no number, only a limit; the forecaster's own chance of this, stated with the estimate: 55%; middle value at least 1.6-fold (0.22 log units) from the limit.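

In this assay compound 3 gives > 50000 nM, which is a limit of the assay. Among the compounds shown here, no step from compound 1 to compound 3 can therefore be read: the limit of > 50000 nM in this assay, at which 3 of the 3 values shown sit. As far as these compounds go, what exchanging the furan-3-yl group does to inhibition in this assay stays open.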